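A few compounds are considered here, and "the series" means these few. Any claim that something is new, unique, unknown or untested is made for them only; others in the source may bear on it.

Going by the values given here, compound 2 `Cc1ccc(OCC(=O)N(Cc2cccs2)c2ccccc2)cc1` stands highest of the two numbers so far in an assay on HEK293 cells for agonist activity at transient receptor potential cation channel subfamily M member 8 (Homo sapiens), read by fluorescence and calcium flux, with a stated time of 15 min (a lower number here means that less compound is needed, a higher number that more compound is needed for the effect), where compound 2 gives 23 nM. Among the compounds with values here, its nearest neighbour, compound 1 `CCN(Cc1cccs1)C(=O)COc1ccc(C)cc1`, gives 8 nM in this assay, and the one measured step, a 2.9-fold higher number from compound 1 to compound 2 (0.46 log units; beyond the scatter), is the only change recorded on the amide-type nitrogen. Compound 3 `Cc1ccc(OCC(=O)N(Cc2cccs2)c2cn[nH]c2)cc1` continues at that same position: 1H-pyrazol-4-yl in place of phenyl on an amide-type nitrogen. Within the data shown here, no measured step covers a 1H-pyrazol-4-yl entering anywhere, so the expectation rests on the single prior step at this nitrogen, which was modest. A step of comparable or smaller size is therefore expected here, with no firm direction; a 1.5-fold higher number from compound 2 to compound 3 (0.18 log units; within the scatter) is the estimated step from compound 2 to compound 3. For compound 3 the estimate in this assay is 35 nM, with a plausible range from 10 nM to 120 nM.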

Compound 3, half-maximal effective concentration: 1.4 nM
Compound 3: the middle estimate sits 25-fold (1.40 log units) above what was measured, and the stated range ends above it.
By their numbers in this assay, from the lowest: compound 3; then compound 1; then compound 2.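

In this assay, the amide-type nitrogen proves able to move the number in either direction: 1H-pyrazol-4-yl in place of phenyl gives a 16-fold lower number from compound 2 to compound 3 (1.22 log units; beyond the scatter) and reverses the rise seen with phenyl in place of ethyl. An aromatic ring on this nitrogen therefore does not itself raise the number, since 1H-pyrazol-4-yl in place of ethyl gives a 5.7-fold lower number from compound 1 to compound 3 (0.76 log units; beyond the scatter) and leaves compound 3 lowest of the three. No measurement available here explains the change, so it remains an observation on these compounds only.

The compounds shown leave open whether the lower number goes with the hydrogen-bond donor, the ring nitrogens or the five-membered ring. A 1-methyl-1H-pyrazol-4-yl or a pyridin-3-yl group on the same nitrogen would begin to separate these features.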